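Morpholine for Piperidine on a Shared Amide Core

The compounds below may be only part of what the source reports. "The series", "measured", "known", "first", "only" and "open" are said of these compounds alone.

For the measured compounds named here, compound 2 `CC(C)(C)c1cc(NC(=O)[C@@H]2CCCCN2C(=O)N2CCCCC2)no1` gives 49 ug/mL in a physicochemical assay for solubility, read by HPLC, at pH 6.8 (on this read-out higher numbers stand for higher solubility and lower numbers for lower solubility), the lowest of the two numbers so far; its nearest neighbour is compound 1 `CC(C)(C)c1cc(NC(=O)[C@@H]2CCCCN2C(=O)C2CCS(=O)(=O)CC2)no1`, which gives 67 ug/mL in this assay. Compound 3 `CC(C)(C)c1cc(NC(=O)[C@@H]2CCCCN2C(=O)N2CCOCC2)no1` differs from compound 2 by morpholin-4-yl in place of piperidin-1-yl on a carbonyl carbon. Going by the values given here, the only measured step that bears on this change is a 1.4-fold lower number from compound 1 to compound 2 (0.14 log units; within the scatter), where one six-membered non-aromatic ring on the carbonyl carbon was exchanged for another and the number stayed within the scatter. The change to compound 3 once more swaps one six-membered non-aromatic ring for another at the same carbonyl carbon, so the expected step in this assay is a 1.6-fold higher number from compound 2 to compound 3 (0.21 log units; within the scatter), a modest rise at most and quite possibly nothing beyond the scatter. Compound 3 is therefore estimated at 80 ug/mL, with a range from 40 ug/mL to 160 ug/mL.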

Compound 3, solubility: 45 ug/mL
Compound 3: the middle estimate sits 1.8-fold (0.25 log units) above what was measured, and the stated range covers the measured number.
By their numbers in this assay, from the lowest: compounds 3, 2 and 1 (each within the scatter of the next).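

The exchange on the carbonyl carbon comes out as a 1.1-fold lower number from compound 2 to compound 3 (0.04 log units; within the scatter) in this assay, and the wider comparison reads as a 1.5-fold lower number from compound 1 to compound 3 (0.17 log units; within the scatter) in the same assay. Morpholin-4-yl, with the hydrogen-bond acceptor that piperidin-1-yl lacks, therefore brings no step beyond the scatter at this position. With three different six-membered non-aromatic rings now on this carbonyl carbon, compounds 1, 2 and 3 cannot be told apart in this assay, and nothing given here accounts for that result.

On these data alone, whether an open-chain amine, a carboxylic acid or a phenyl ring on this carbonyl carbon would give a step beyond the scatter remains open. As far as these compounds go, it is also open whether morpholin-4-yl in place of piperidin-1-yl would give a similar step on a different core.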